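Indole on the Aromatic Nitrogen of a NAE Inhibitor Series

The source may report more compounds than this note shows. Statements on the series, on what has been measured and on what is new or still open speak of the compounds shown alone.

Measured so far:
compound 1 `NS(=O)(=O)OC[C@@H]1C[C@@H](n2nnc3c(NCc4cccs4)ncnc32)C[C@@H]1O` gives 15.9 nM in an assay on a protein complex for inhibition of NEDD8 activating enzyme (Homo sapiens), read by HTRF, with a stated time of 2 h, in the presence of a further agent that is not named here; a higher number here means a weaker inhibitor, a lower number a stronger inhibitor;
compound 2 `NS(=O)(=O)OC[C@@H]1C[C@@H](n2nnc3c(NCCCc4ccccc4)ncnc32)C[C@@H]1O` gives 149 nM in this assay.

Compound 1 holds the lowest number of the two. Going by the values given here, the only measured step, a 9.4-fold higher number from compound 1 to compound 2 (0.97 log units; beyond the scatter), shows that this region of the core responds to change. Compound 3 `NS(=O)(=O)OC[C@@H]1C[C@@H](n2nnc3c(Nn4ccc5ccccc54)ncnc32)C[C@@H]1O` differs from compound 1 by 1H-indol-1-yl in place of (thiophen-2-yl)methyl on a nitrogen on an aromatic ring. That step removes the saturated chain carbon altogether, a larger change than in the measured step, so a weaker inhibitor is expected, roughly a 16-fold higher number from compound 1 to compound 3 (1.20 log units; beyond the scatter). Compound 3 is therefore estimated at 250 nM, within 40 nM to 2000 nM.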

Compound 3, half-maximal inhibitory concentration: > 10000 nM
Compound 3 was reported as a limit; the forecaster's own chance of this, stated with the estimate: 10%; middle value at least 40-fold (1.60 log units) from the limit.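

Compound 3 stands only as a limit of the assay: the limit of > 10000 nM in this assay, at which 1 of the 3 values shown sits. The earlier compounds shown here showed that this position responds to change, but the replacement by 1H-indol-1-yl gives far larger steps, an at least 620-fold higher number from compound 1 to compound 3 (2.79 log units; beyond the scatter) and an at least 67-fold higher number from compound 2 to compound 3 (1.82 log units; beyond the scatter), than the one seen before, a 9.4-fold higher number from compound 1 to compound 2 (0.97 log units; beyond the scatter). As far as these compounds go, both steps are themselves bounded by the limit, so their true size remains unknown.

The compounds shown do not separate the loss of the saturated chain carbon from the entry of the indole. A 1H-indol-1-ylmethyl group on the same nitrogen would bear on that question.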